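The source may hold more compounds than are shown below. What is called first, only, known or untested is meant among the compounds shown, and "the series" means these compounds.

Of the compounds shown here, three that share one core have so far been measured in a functional assay on A-431 cells (Homo sapiens) for antiproliferative activity, read by MTT assay, with a stated time of 72 h; a higher number here means a weaker inhibitor, a lower number a stronger inhibitor. Compound 3 `NS(=O)(=O)c1ccc(NC(=S)Nc2ccc3ncnc(Nc4ccc(Cl)c(C(F)(F)F)c4)c3c2)cc1` gives 18200 nM in this assay, the lowest of the three numbers. Compound 2 `NS(=O)(=O)c1ccc(NC(=S)Nc2ccc3ncnc(Nc4cccc(C(F)(F)F)c4)c3c2)cc1` gives 21700 nM, and compound 1 `NS(=O)(=O)c1ccc(NC(=S)Nc2ccc3ncnc(Nc4ccc(F)c(Cl)c4)c3c2)cc1` gives 37600 nM. The steps between them are small: a 1.7-fold lower number from compound 1 to compound 2 (0.24 log units; within the scatter), a 1.2-fold lower number from compound 2 to compound 3 (0.08 log units; within the scatter), and the largest, a 2.1-fold lower number from compound 1 to compound 3 (0.32 log units; beyond the scatter).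

Compound 4 `NS(=O)(=O)c1ccc(NC(=S)Nc2ccc3ncnc(Nc4ccc(F)c(Br)c4)c3c2)cc1` is the next member. It differs from compound 3 by 3-bromo-4-fluorophenyl in place of 4-chloro-3-(trifluoromethyl)phenyl on a nitrogen on an aromatic ring. The incoming 3-bromo-4-fluorophenyl group closely resembles the 3-chloro-4-fluorophenyl group of compound 1, bromine standing in for chlorine. The measured step that this change is expected roughly to undo is a 2.1-fold lower number from compound 1 to compound 3 (0.32 log units; beyond the scatter). On that basis a modest rise in this assay is expected, of about a 1.8-fold higher number from compound 3 to compound 4 (0.25 log units; within the scatter), bringing compound 4 back toward the number seen for compound 1. Compound 4 is therefore estimated at 32000 nM, with a likely range from 15000 nM to 65000 nM.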

Compound 4, half-maximal inhibitory concentration: 18200 nM
Estimate against measurement, compound 4: 1.8-fold (0.25 log units) above; the measured number falls inside the stated range.
By their numbers in this assay, from the lowest: compounds 3, 4, 2 and 1 (each within the scatter of the next, the first and the last beyond it).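

The closest pair is the most telling: bromo in place of chloro on an aromatic carbon, a change of a single atom, gives a 2.1-fold lower number from compound 1 to compound 4 (0.32 log units; beyond the scatter) in this assay. A ring with no trifluoromethyl group can also match the rings that carry one, with no change at the digits printed from compound 3 to compound 4 (within the scatter) and a 1.2-fold lower number from compound 2 to compound 4 (0.08 log units; within the scatter), although compound 1, also without trifluoromethyl, stands beyond the scatter of compound 3. Nothing shown here explains why these exchanges on the nitrogen give these numbers.

On these data alone, whether iodo in place of bromo would extend the step seen from chloro to bromo remains open. So does whether a phenyl ring bearing a methoxy group or an amine, rather than halogen or trifluoromethyl, would move the number further.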